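Swapping the pyrazole ring in a cell growth inhibitor

A few compounds are considered here, and "the series" means these few. Any claim that something is new, unique, unknown or untested is made for them only; others in the source may bear on it.

Of the compounds shown here, three sharing one core have been tested in a functional assay on MV4-11 cells (Homo sapiens) for antiproliferative activity, with a stated time of 6 days, tested at 6.25 uM; a higher number here means a stronger effect of the compound at the concentration tested, a lower number a weaker effect. Compound 1 `CNC(=O)N1CCCc2ccc(NC(=O)c3ccc(-c4cc[nH]n4)cc3)cc21` gives 99.1%. Compound 2 `CNC(=O)N1CCCc2ccc(NC(=O)c3cccc(-c4ccn(C)n4)c3)cc21` gives 99.5%, which stands highest of the three numbers, though its gap to compound 1 lies within the scatter of repeated measurements. Within the data shown here, compound 3 `CNC(=O)N1CCCc2ccc(NC(=O)c3ccc(-c4ccncc4)cc3)cc21` gives 88.7%, the only number clearly set apart from the other two.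

Among the measured compounds shown here, one measured step bears on what follows: a number 10.4 percentage points lower from compound 1 to compound 3 (beyond the scatter). The new compound 4 `CNC(=O)N1CCCc2ccc(NC(=O)c3cccc(-c4cnn(C(C)=O)c4)c3)cc21` differs from compound 2 in the following way: 1-acetyl-1H-pyrazol-4-yl in place of 1-methyl-1H-pyrazol-3-yl on an aromatic carbon. Here the five-membered ring stays a pyrazole and only its attachment point and its substituent change, whereas the step from compound 1 to compound 3 replaced the pyrazole with a pyridine and still cost only a modest amount. Compound 2 already sits close to complete inhibition, so there is little room for an upward move, and a small downward move, or none beyond the scatter, is the more likely outcome.

Compound 4 is therefore estimated at 95%, with a range from 82% to 99.8%. This estimate means an expected step of a number 4.5 percentage points lower from compound 2 to compound 4 (within the scatter).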

Compound 4, a percentage reported as inhibition, at one concentration (the size of the read-out at that concentration, not a potency): 82%
Compound 4: middle estimate off by 13 percentage points, on the high side; measured number inside the range.
By their numbers in this assay, from the lowest: compounds 4 and 3 (each within the scatter of the next); then compounds 1 and 2 (each within the scatter of the next).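

Keeping a pyrazole at this place does not by itself keep the effect: in this assay, 1-acetyl-1H-pyrazol-4-yl in place of 1-methyl-1H-pyrazol-3-yl gives a number 17.5 percentage points lower from compound 2 to compound 4 (beyond the scatter). The position, on an aromatic carbon of a six-membered aromatic ring of carbon only and meta to a large group, therefore responds to changes made within the five-membered ring and not only to replacing that ring outright. This single change moves the ring's attachment point and swaps its substituent together, so the step cannot separate the two, and no measurement at hand offers a reason for the drop.

A 1-methyl-1H-pyrazol-4-yl group or a 1-acetyl-1H-pyrazol-3-yl group at this place would pull the two changes apart, showing whether the attachment point, the acetyl group or their combination accounts for the step. On these data alone, it also remains open how this assay would read for a 1H-pyrazol-4-yl ring carrying only hydrogen on its nitrogen, or for the same ring carrying an ethyl group or a longer chain ending in an amine there.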